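Amine substituent variation on the shared diaryl ether core

The compounds below may be only part of what the source reports. "The series", "measured", "known", "first", "only" and "open" are said of these compounds alone.

Compound 3 `COc1ccc(CCCNCc2c(OC)cc(Oc3cccc(Nc4ccccc4)c3)cc2OC)cc1` gives 2540 nM in a functional assay on DLD-1 cells (Homo sapiens) for inhibition, read by MTT assay, with a stated time of 72 h (a lower number here means a stronger inhibitor, a higher number a weaker inhibitor), the lowest of the two numbers obtained so far. Compound 1 `COc1cc(Oc2cccc(Nc3ccccc3)c2)cc(OC)c1CNCc1ccc(Br)cc1` gives 3520 nM in this assay; the step of a 1.4-fold lower number from compound 1 to compound 3 (0.14 log units; within the scatter) lies within the scatter, so the two compounds cannot be ordered. For compound 2 `COc1cc(Oc2cccc(Nc3ccccc3)c2)cc(OC)c1CNC(C)C` this assay reports a limit, > 20000 nM, and not a number (the limit of > 20000 nM in this assay, at which 1 of the 3 values shown sits). The steps of an at least 5.6-fold higher number from compound 1 to compound 2 (0.75 log units; beyond the scatter) and an at least 7.8-fold lower number from compound 2 to compound 3 (0.89 log units; beyond the scatter) both place the isopropyl on the amine nitrogen well behind the two aryl-bearing substituents.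

Compound 4 `COc1cc(Oc2cccc(Nc3ccccc3)c2)cc(OC)c1CN[C@H](C)c1ccccc1` differs from compound 3 by 1-phenylethyl in place of 3-(4-methoxyphenyl)propyl on an amine nitrogen. The entering group carries an aromatic ring, as do the groups of compound 1 and compound 3, and unlike the isopropyl of compound 2. Since the step of a 1.4-fold lower number from compound 1 to compound 3 (0.14 log units; within the scatter) showed no change beyond the scatter between the two aryl-bearing groups, the expected step of a 1.6-fold higher number from compound 3 to compound 4 (0.20 log units; within the scatter) is small, with the remaining uncertainty leaning toward a higher number. Compound 4 is therefore estimated at 4000 nM, with a range from 1500 nM to 12000 nM.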

Compound 4, half-maximal inhibitory concentration: 8570 nM
For compound 4 the middle estimate is 2.1-fold (0.33 log units) below the measured one, within the range that was stated.
By their numbers in this assay, from the lowest: compounds 3 and 1 (each within the scatter of the next); then compound 4. At a limit, above all of these: compound 2.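

In this assay, an aromatic ring on the amine nitrogen does not by itself fix the number, as the aryl-bearing groups, so far inseparable, now differ: a 3.4-fold higher number from compound 3 to compound 4 (0.53 log units; beyond the scatter), and a 2.4-fold higher number from compound 1 to compound 4 (0.39 log units; beyond the scatter). Which aryl-bearing group is attached therefore matters, and 1-phenylethyl falls behind both 3-(4-methoxyphenyl)propyl and 4-bromobenzyl. It still stands ahead of isopropyl, an at least 2.3-fold lower number from compound 2 to compound 4 (0.36 log units; beyond the scatter), though this step starts from a limit and not a number: the limit of > 20000 nM in this assay, at which 1 of the 4 values shown sits.

From the compounds shown here alone, whether the higher number of compound 4 follows from its branched carbon, its defined stereocentre or the loss of the methoxy group stays open. An unsubstituted benzyl group, a 2-phenylethyl group and the opposite stereoisomer of 1-phenylethyl on the amine nitrogen would help separate these readings.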